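From furan-3-yl to thiophen-2-yl on a shared core

The source may hold more compounds than are shown below. What is called first, only, known or untested is meant among the compounds shown, and "the series" means these compounds.

- Compound 1 `CSc1ncnc2c1c(-c1cccs1)cn2[C@@H]1O[C@H](CO)[C@@H](O)[C@H]1O`: > 20000 nM (a limit)
- Compound 2 `CNc1ncnc2c1c(-c1ccoc1)cn2[C@@H]1O[C@H](CO)[C@@H](O)[C@H]1O`: > 20000 nM (a limit)

In a functional assay on HepG2 cells (Homo sapiens) for antiproliferative activity, read by XTT assay, with a stated time of 72 h (on this read-out lower numbers stand for stronger inhibition and higher numbers for weaker inhibition), compound 2 gives > 20000 nM, which is a limit and not a number. The picture so far is a single one: the limit of > 20000 nM in this assay, at which 2 of the 2 values shown sit. Compound 3 `CNc1ncnc2c1c(-c1cccs1)cn2[C@@H]1O[C@H](CO)[C@@H](O)[C@H]1O` differs from compound 2 in one place, with thiophen-2-yl in place of furan-3-yl on an aromatic carbon. Compound 1 also carries thiophen-2-yl, and it gives > 20000 nM, again a limit. Among the measured compounds shown here, no measured step shows what this exchange does in this assay, so only a small change toward stronger inhibition is expected, perhaps none beyond the scatter. The expected step is an at least 1.3-fold lower number from compound 2 to compound 3 (0.12 log units; that floor lies within the scatter). Another limit is quite possible. For compound 3 the estimated value is 15000 nM, with an expected range from 1500 nM to 30000 nM.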

Compound 3, half-maximal inhibitory concentration: > 20000 nM
Compound 3: a limit, no number; the forecaster's own chance of this, stated with the estimate: 60%; at least 1.3-fold (0.12 log units) between middle value and limit.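

Compound 3 also ends at a limit, not a number, so the steps to it from compound 1 and from compound 2 cannot be read: the limit of > 20000 nM in this assay, at which 3 of the 3 values shown sit.

Going by these compounds, whether either exchange, thiophen-2-yl for furan-3-yl or methylamino for methylsulfanyl, changes the inhibition at all stays open.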